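Amino Replaces Butyl in a Benzophenone Amide Series

A few compounds are considered here, and "the series" means these few. Any claim that something is new, unique, unknown or untested is made for them only; others in the source may bear on it.

Compound 1 `CCCCCC(=O)NCC(=O)N(C)c1ccc(Cl)cc1C(=O)c1ccccc1Cl` was tested in a functional assay on the whole organism for antagonist activity, with Mus musculus as the target (a higher number here means that more compound is needed for the effect, a lower number that less compound is needed), and gives 1.9 mg/kg. Compound 2 `NCC(=O)NCC(=O)Nc1ccc([N+](=O)[O-])cc1C(=O)c1ccccc1Cl` in this assay gives 2.64 mg/kg, and these two numbers lie within the usual scatter of each other, so neither compound can be called more potent. Compound 3 `CN(C(=O)CNC(=O)CN)c1ccc(Cl)cc1C(=O)c1ccccc1Cl` is not yet measured. It differs from compound 1 in one place: amino in place of butyl on a saturated chain carbon bound to a carbonyl carbon. Among the measured compounds shown here, with no measured pair showing this change, the step of a 1.2-fold higher number from compound 1 to compound 3 (0.08 log units; within the scatter) is expected to stay within the scatter. Compound 3 is expected to give 2.3 mg/kg, with a range from 1.2 mg/kg to 4.5 mg/kg.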

Compound 3, dose for half-maximal effect: 0.58 mg/kg
Compound 3: the middle estimate sits 4.0-fold (0.60 log units) above what was measured; measured number outside the range, below it.
By their numbers in this assay, from the lowest: compound 3; then compounds 1 and 2 (each within the scatter of the next).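

In this assay, amino in place of butyl on a saturated chain carbon bound to a carbonyl carbon gives a 3.3-fold lower number from compound 1 to compound 3 (0.52 log units; beyond the scatter) and so lies beyond the scatter. The butyl is therefore not needed at this place, and the shorter amino-bearing chain does better in this pair. No measurement here explains the shift.

A single pair cannot show whether the amino group itself matters or merely the loss of the butyl. A hydroxyl, a dimethylamino group or a longer chain ending in an amine at this place remains untested in the compounds shown.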